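Methyl on the dienyl chain of a prostanoid analogue

The source may report more compounds than this note shows. Statements on the series, on what has been measured and on what is new or still open speak of the compounds shown alone.

Compound 1 `C/C=C\C=C\[C@](C)(O)C/C=C/[C@H]1[C@H](O)CC(=O)[C@@H]1CC/C=C\CCC(=O)OC` is assessed in a functional assay on the whole organism with Rattus norvegicus as the target (a lower number here means that less compound is needed, a higher number that more compound is needed for the effect), where compound 1 gives 0.306 mg/kg. Among the numbers shown, this is the lowest of the two; its nearest neighbour is compound 2 `C/C=C(C)\C=C\[C@](C)(O)C/C=C/[C@H]1[C@H](O)CC(=O)[C@@H]1CC/C=C\CCC(=O)OC`, which in this assay gives 1.23 mg/kg, a gap that the step of a 4.0-fold higher number from compound 1 to compound 2 (0.60 log units; beyond the scatter) shows to lie beyond the scatter. Compound 3 `COC(=O)CC/C=C\CC[C@H]1C(=O)C[C@@H](O)[C@@H]1/C=C/C[C@@](C)(O)/C=C/C1=CCCC1` reaches only a limit of this assay, reported as > 3.16 mg/kg. The steps of an at least 10-fold higher number from compound 1 to compound 3 (1.01 log units; beyond the scatter) and an at least 2.5-fold higher number from compound 2 to compound 3 (0.40 log units; beyond the scatter) therefore rest on that limit (the limit of > 3.16 mg/kg in this assay, at which 1 of the 3 values shown sits).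

Compound 4 `C/C=C(C)/C=C/[C@](C)(O)C/C=C/[C@H]1[C@H](O)CC(=O)[C@@H]1CC/C=C\CCC(=O)OC` has not yet been measured. It differs from compound 1 in one place: 1-methylprop-1-en-1-yl in place of prop-1-en-1-yl on a double-bonded chain carbon bound to a double-bonded chain carbon. Compound 2 carries the same named group in the same place relative to compound 1, so the step from compound 1 to compound 2 is the closest guide, and it was a modest rise in the dose for half-maximal effect. Compound 4 is not the same structure as compound 2, so the transfer is uncertain, but the direction should hold. In this assay compound 4 is therefore expected to need more compound than compound 1, by about a 3.3-fold higher number from compound 1 to compound 4 (0.51 log units; beyond the scatter). The estimate for compound 4 is 1 mg/kg, with a range from 0.4 mg/kg to 2.5 mg/kg.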

Compound 4, dose for half-maximal effect: 0.185 mg/kg
Estimate against measurement, compound 4: 5.4-fold (0.73 log units) above; measured number below the stated range.
By their numbers in this assay, from the lowest: compounds 4 and 1 (each within the scatter of the next); then compound 2. At a limit, above all of these: compound 3.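

In this assay the added methyl does not by itself shift the dose: the step to 1-methylprop-1-en-1-yl in place of prop-1-en-1-yl on a double-bonded chain carbon bound to a double-bonded chain carbon is a 1.7-fold lower number from compound 1 to compound 4 (0.22 log units; within the scatter) and leaves the two compounds indistinguishable. The rise seen earlier with compound 2 therefore cannot be read as the effect of the methyl alone, for the same group in its other drawn geometry gives a clear separation (a 6.6-fold lower number from compound 2 to compound 4 (0.82 log units; beyond the scatter)), and this gap can be traced only to the double bond as drawn: the fact that compounds 2 and 4 differ only in the configuration as drawn. The step from the cyclopent-1-en-1-yl group is large but rests on a limit, not on a number, for compound 3 (an at least 17-fold lower number from compound 3 to compound 4 (1.23 log units; beyond the scatter)): the limit of > 3.16 mg/kg in this assay, at which 1 of the 4 values shown sits.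

The compounds shown leave open whether ethyl or phenyl in place of this methyl would keep the dose of compound 4 in the same range, and whether the geometry of the double bond would matter as much with those groups. They also leave open how far the result for the cyclopent-1-en-1-yl group depends on its ring, since its value is only a limit.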